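This account rests on a few compounds, and the source may have more. Where it says the series, first, only, none or still open, it means among the compounds named here.

The measured compounds and their numbers:

compound 1, `Cc1c(OCCCCOc2ccc(F)c(C(=O)O)c2)ccc(C(=O)CC(C)(C)C)c1O`, 94.6%
compound 2, `Cc1c(OCCCCOc2ccc(C(=O)CC(C)(C)C)c(O)c2C)cccc1C(=O)O`, 95.8%
compound 3, `Cc1c(OCCCCOc2ccc(C(=O)O)c(Cl)c2)ccc(C(=O)CC2CCCC2)c1O`, 80.8%

All three were tested in an assay on HEK293 cells for positive allosteric modulation of metabotropic glutamate receptor 2 (Rattus norvegicus), read by thallium flux, with a stated time of 2.5 min; on this read-out lower numbers stand for smaller maximal responses and higher numbers for larger maximal responses. Compound 1 stands second highest of the three. Its nearest neighbour is compound 2, and the step of a number 1.2 percentage points higher from compound 1 to compound 2 (within the scatter) lies within the scatter, so the two compounds cannot be told apart on this read-out. Compound 3 is furthest away: its value is lower than that of compound 1 by an amount beyond the scatter, but compound 3 differs from compound 1 in more than one place, so no single cause can be read from that pair.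

Compound 4, `Cc1c(OCCCCOc2ccc(F)c(C(=O)O)c2)ccc(C(=O)C(C)C)c1O`, has not yet been measured. It differs from compound 1 in one place: isopropyl in place of neopentyl on a carbonyl carbon. Among the compounds with values here, the only step measured so far, from compound 1 to compound 2, changes the aryl group on the chain and leaves the carbonyl side untouched, so it gives no direct guidance for this change. Within the data shown here, with no measured step at the carbonyl carbon, the expectation rests on the general closeness of compounds 1 and 2 and on the lower value of compound 3, which carries a different group at that same carbonyl.

For compound 4 the expected step is a number 7.6 percentage points lower from compound 1 to compound 4 (within the scatter), a modest decrease that may still fall within the scatter. Compound 4 is therefore estimated at 87%, with a range from 72% to 100%.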

Compound 4, largest response reached (reported as percent of maximum), in percent of the reference or control that the assay uses: 74.1%
Compound 4: the middle estimate sits 12.9 percentage points above what was measured, and the stated range covers the measured number.
By their numbers in this assay, from the lowest: compounds 4 and 3 (each within the scatter of the next); then compounds 1 and 2 (each within the scatter of the next).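

In this assay, the first single change measured at the carbonyl carbon, isopropyl in place of neopentyl, gives a number 20.5 percentage points lower from compound 1 to compound 4 (beyond the scatter). Within the data shown here, this shows that the group on this carbon matters for the maximal response, whereas the only earlier single change, on the aryl group at the far end of the chain, gave a number 1.2 percentage points higher from compound 1 to compound 2 (within the scatter) and left the two compounds indistinguishable. The change takes out neopentyl with 5 heavy atoms and puts in isopropyl with 3, but nothing measured here explains why the response falls with this swap.

One pair cannot show whether the response follows the number of carbons in this group or the way they are arranged, and a straight butyl chain, a tert-butyl group or a group carrying an amine on the same carbonyl carbon would help to separate these possibilities. As far as these compounds go, it also remains open whether isopropyl would lower the response to a similar degree when paired with the 3-carboxy-2-methylphenyl group of compound 2.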